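Methyl on the indole of compound 3: outlook for compound 4

The compounds below may be only part of what the source reports. "The series", "measured", "known", "first", "only" and "open" are said of these compounds alone.

Measured so far:
compound 1, `CC(C)C[C@H](N)c1cc(C(F)(F)F)ccc1N1CCN(C(=O)CCc2ccccc2O)CC1`, in an assay on HEK293 cells for displacement of a labelled ligand from Melanocortin receptor 4 (Homo sapiens) (a higher number here means a weaker inhibitor, a lower number a stronger inhibitor), compound 1 gives 3300 nM
compound 2, `CC(C)C[C@H](N)c1cc(C(F)(F)F)ccc1N1CCN(C(=O)CCc2ccc(O)cc2)CC1`, compound 2 gives only a limit of this assay, > 10000 nM
compound 3, `CC(C)C[C@H](N)c1cc(C(F)(F)F)ccc1N1CCN(C(=O)CCc2c[nH]c3ccccc23)CC1`, compound 3 gives 640 nM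

Compound 3 has the lowest of the two numbers in hand; the nearest number is that of compound 1, and the step is a 5.2-fold lower number from compound 1 to compound 3 (0.71 log units; beyond the scatter). Compound 2 sits at the limit described by the limit of > 10000 nM in this assay, at which 1 of the 3 values shown sits. The step of an at least 15-fold lower number from compound 2 to compound 3 (1.19 log units; beyond the scatter) is therefore only a lower bound, as is an at least 3.0-fold higher number from compound 1 to compound 2 (0.48 log units; beyond the scatter).

Compound 4, `Cc1[nH]c2ccccc2c1CCC(=O)N1CCN(c2ccc(C(F)(F)F)cc2[C@@H](N)CC(C)C)CC1`, differs from compound 3 by methyl in place of hydrogen on an aromatic carbon. Among the measured compounds shown here, none of the measured steps bears directly on this change: each of them exchanged the whole aromatic group on the saturated chain carbon two bonds along the chain from the carbonyl carbon, and none altered the indole itself. There is thus no measured basis for a shift in either direction, and the expected step of a 1.2-fold lower number from compound 3 to compound 4 (0.07 log units; within the scatter) is taken to lie within the scatter. Compound 4 is estimated at 550 nM, with a range from 180 nM to 1700 nM.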

Compound 4, inhibition constant: 1600 nM
Compound 4: middle estimate off by 2.9-fold (0.46 log units), on the low side; the range from low to high includes it.
By their numbers in this assay, from the lowest: compound 3; then compound 4; then compound 1. At a limit, above all of these: compound 2.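

In this assay, methyl next to the ring nitrogen of the indole is not a silent change: a 2.5-fold higher number from compound 3 to compound 4 (0.40 log units; beyond the scatter), the first read-out of a change made on the indole itself rather than an exchange of the whole aromatic group. 2-Methyl-1H-indol-3-yl still keeps an edge over 2-hydroxyphenyl, with a 2.1-fold lower number from compound 1 to compound 4 (0.31 log units; beyond the scatter), although this is a smaller step than a 5.2-fold lower number from compound 1 to compound 3 (0.71 log units; beyond the scatter). The remaining step, an at least 6.2-fold lower number from compound 2 to compound 4 (0.79 log units; beyond the scatter), rests on a limit of the assay and is only a bound: the limit of > 10000 nM in this assay, at which 1 of the 4 values shown sits.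

Going by these compounds, whether the higher number belongs to methyl alone or to any group on this carbon stays open; ethyl or chlorine at the same place would bear on that. Also open, on these data alone, is how fluorine or methoxy elsewhere on the indole would read in this assay.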